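This account rests on a few compounds, and the source may have more. Where it says the series, first, only, none or still open, it means among the compounds named here.

Of the compounds shown here, three sharing one core have been measured in an assay for inhibition of protein disulfide-isomerase (Homo sapiens), with a stated time of 1 h; on this read-out lower numbers stand for stronger inhibition and higher numbers for weaker inhibition. Compound 1 `CCc1ccc(C(Nc2ccccn2)c2ccc3cccnc3c2O)cc1` gives 170 nM and compound 2 `Oc1c(C(Nc2ccccn2)c2ccc(Cl)cc2)ccc2cccnc12` gives 170 nM, a step of no change at the digits printed from compound 1 to compound 2 (within the scatter). Compound 3 `Cc1ccc(C)c(C(Nc2ccccn2)c2ccc3cccnc3c2O)c1` gives 730 nM, the highest of the three numbers, since a 4.3-fold higher number from compound 1 to compound 3 (0.63 log units; beyond the scatter) and a 4.3-fold higher number from compound 2 to compound 3 (0.63 log units; beyond the scatter). Compound 4 `COc1cccc(C(Nc2ccccn2)c2ccc3cccnc3c2O)c1` is not yet measured; it differs from compound 3 in one place: 3-methoxyphenyl in place of 2,5-dimethylphenyl on a saturated chain carbon bound to an aromatic carbon and a nitrogen on an aromatic ring. For the measured compounds named here, no measured step brings in a 3-methoxyphenyl, so only the two modest steps into compound 3 bear on this change, and in both the move to a 2,5-dimethylphenyl went with a higher number. Leaving that group may therefore bring the number down somewhat, with the size uncertain. Compound 4 is expected to show a 2.1-fold lower number from compound 3 to compound 4 (0.32 log units; beyond the scatter), estimated at 350 nM within a range of 120 nM to 1000 nM.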

Compound 4, half-maximal inhibitory concentration: 2860 nM
Compound 4: the middle estimate sits 8.2-fold (0.91 log units) below what was measured; measured number above the stated range.
By their numbers in this assay, from the lowest: compounds 1 and 2 (each within the scatter of the next); then compound 3; then compound 4.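

Leaving the 2,5-dimethylphenyl did not lower the number: the 3-methoxyphenyl gave a 3.9-fold higher number from compound 3 to compound 4 (0.59 log units; beyond the scatter) in this assay and is the least favourable of the four groups at this position. The gap is wider against the other two groups, with a 17-fold higher number from compound 2 to compound 4 (1.23 log units; beyond the scatter) and a 17-fold higher number from compound 1 to compound 4 (1.23 log units; beyond the scatter) showing that this position can shift the number by a large amount. Nothing measured here explains the rise.

On these data alone, how an amine, a carboxylic acid or a longer chain on this aromatic ring would behave remains open.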